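Sulfanyl to Sulfonyl in a Series of Phenolic Anilides

A few compounds are considered here, and "the series" means these few. Any claim that something is new, unique, unknown or untested is made for them only; others in the source may bear on it.

Of the compounds shown here, three have been tested in a functional assay on VCaP cells (Homo sapiens) for antiproliferative activity, read by fluorescence and propidium iodide staining, with a stated time of 96 h; a higher number here means a weaker inhibitor, a lower number a stronger inhibitor. Compound 1 `O=C(Nc1cc(C(F)(F)F)ccc1C(F)(F)F)c1ccc(Sc2ccc(O)cc2)cc1` gives 10900 nM. Compound 3 `O=C(Nc1cc(C(F)(F)F)ccc1C(F)(F)F)c1ccc(S(=O)(=O)c2ccc(O)cc2)cc1` shares its core and differs only by (4-hydroxyphenyl)sulfonyl in place of (4-hydroxyphenyl)sulfanyl on an aromatic carbon; compound 3 gives 30500 nM, a step of a 2.8-fold higher number from compound 1 to compound 3 (0.45 log units; beyond the scatter). Compound 2 `O=C(Nc1cccc(S(F)(F)(F)(F)F)c1)c1ccc(Sc2ccc(O)cc2)cc1` carries a different core, and how it differs from the core of compound 1 is not broken down here; in this assay compound 2 gives 6100 nM, a number within the scatter of compound 1 but well apart from compound 3.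

Compound 4 `O=C(Nc1cccc(S(F)(F)(F)(F)F)c1)c1ccc(S(=O)(=O)c2ccc(O)cc2)cc1` has not yet been measured. It is related to compound 2 in the same way that compound 3 is related to compound 1: (4-hydroxyphenyl)sulfonyl in place of (4-hydroxyphenyl)sulfanyl on an aromatic carbon, with the place described in the same words in both pairs, so this is the same change. Because the earlier step was a 2.8-fold higher number from compound 1 to compound 3 (0.45 log units; beyond the scatter), a step of roughly that size is expected from compound 2 to compound 4, estimated as a 2.8-fold higher number from compound 2 to compound 4 (0.45 log units; beyond the scatter), resting on a single prior example. On that basis compound 4 is expected to give about 17000 nM, plausibly between 8000 nM and 40000 nM.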

Compound 4, half-maximal inhibitory concentration: 10800 nM
Beside the measured number, compound 4's estimate is 1.6-fold (0.20 log units) above it, within the range that was stated.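

In this assay, putting (4-hydroxyphenyl)sulfonyl in place of (4-hydroxyphenyl)sulfanyl on the core of compound 2 gives a 1.8-fold higher number from compound 2 to compound 4 (0.25 log units; within the scatter), so this step alone cannot be told apart from the spread of repeated measurements. Set beside the same change on the core of compound 1, the two steps cannot be told apart either: the same change on two cores in this assay, a 2.8-fold higher number (0.45 log units; beyond the scatter) from compound 1 to compound 3 and a 1.8-fold higher number (0.25 log units; within the scatter) from compound 2 to compound 4, 1.6-fold (0.20 log units) apart, within the scatter of two such steps. Within the data shown here, this shows that the change behaves alike on these two cores as far as the data can tell, but it does not give a rule for other cores, since only two pairs stand behind it and only one of the two steps lies beyond the scatter.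

All the compounds shown keep the 4-hydroxyphenyl group, so it stays open whether the same step holds with an amine or a carboxylic acid in place of the hydroxy group. Also open, from the compounds shown here alone, is what a link through a plain oxygen or a methylene group would give in place of the sulfur.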